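The compounds below may be only part of what the source reports. "The series", "measured", "known", "first", "only" and "open" are said of these compounds alone.

Compound 1 `COc1ccc(NC(=O)C2CCN(C/C=C/c3ccccc3)CC2)cc1`: 88800 nM
Compound 2 `COc1cccc(NC(=O)C2CCN(C/C=C/c3ccccc3)CC2)c1`: 78600 nM
Compound 3 `COc1ccccc1NC(=O)C1CCN(C/C=C/c2ccccc2)CC1`: 91200 nM

These values come from a functional assay on HepG2 cells (Homo sapiens) for inhibition, read by MTT assay, with a stated time of 72 h; a higher number here means a weaker inhibitor, a lower number a stronger inhibitor. Compound 3 stands level with the other two, with a 1.0-fold higher number from compound 1 to compound 3 (0.01 log units; within the scatter) and a 1.2-fold higher number from compound 2 to compound 3 (0.06 log units; within the scatter). Compound 4 `O=C(Nc1ccccn1)C1CCN(C/C=C/c2ccccc2)CC1` differs from it by pyridin-2-yl in place of 2-methoxyphenyl on an amide-type nitrogen, which puts pyridin-2-yl in place of 2-methoxyphenyl on an amide-type nitrogen. The measured steps bearing on this only relocate the methoxy group, and the remaining one is a 1.1-fold lower number from compound 1 to compound 2 (0.05 log units; within the scatter). All three are small, but none replaces the ring itself, so the evidence is indirect. No direction can be assigned, and no change beyond the scatter is expected. The estimated step is a 1.1-fold lower number from compound 3 to compound 4 (0.03 log units; within the scatter). For compound 4, the estimated value is 85000 nM, with an expected range of 40000 nM to 170000 nM.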

Compound 4, half-maximal inhibitory concentration: 51100 nM
Compound 4: middle estimate off by 1.7-fold (0.22 log units), on the high side; measured number inside the range.
By their numbers in this assay, from the lowest: compounds 4, 2, 1 and 3 (each within the scatter of the next).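

Among the compounds shown here, this is the first step that replaces the ring itself on the amide-type nitrogen rather than relocating the methoxy group, and in (this assay) pyridin-2-yl stands level with all three methoxyphenyl compounds: (a 1.8-fold lower number from compound 3 to compound 4 (0.25 log units; within the scatter)), (a 1.5-fold lower number from compound 2 to compound 4 (0.19 log units; within the scatter)) and (a 1.7-fold lower number from compound 1 to compound 4 (0.24 log units; within the scatter)). Thus, a ring with a hetero atom and no methoxy group leaves the number within the scatter. Nothing available explains this result. Going by these compounds, whether pyridin-4-yl, or a phenyl ring carrying an amine or a carboxylic acid, would give a step beyond the scatter at this nitrogen stays open.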